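The source may report more compounds than this note shows. Statements on the series, on what has been measured and on what is new or still open speak of the compounds shown alone.

Measured so far in a functional assay on BGC-823 cells (Homo sapiens) for inhibition, read by MTT assay, with a stated time of 72 h (a lower number here means a stronger inhibitor, a higher number a weaker inhibitor), are two compounds:
- compound 1 `O=C1/C(=C\c2ccccc2)c2c(ncn2COCc2ccccc2)CCN1Cc1ccc(-c2ccccc2)cc1` gives 81000 nM here
- compound 2 `COc1ccc(CN2CCc3ncn(COCc4ccccc4)c3/C(=C/c3ccccc3)C2=O)cc1` gives 71600 nM here

Compound 2, at 71600 nM here, stands level with compound 1 within the scatter. Compound 3 `Cc1ccccc1CN1CCc2ncn(COCc3ccccc3)c2/C(=C/c2ccccc2)C1=O` keeps their shared core and differs from compound 2 by one swap: 2-methylphenyl in place of 4-methoxyphenyl on a saturated chain carbon bound to an amide-type nitrogen in a ring in short, 2-methylphenyl in place of 4-methoxyphenyl on a saturated chain carbon bound to an amide-type nitrogen in a ring. For the measured compounds named here, one measured step bears on this. That step, a 1.1-fold lower number from compound 1 to compound 2 (0.05 log units; within the scatter) in size, also altered the group on this benzyl and stayed within the scatter. Going by the values given here, it is thin evidence, and no measured compound carries a 2-methylbenzyl. So in this assay no step beyond the scatter is expected. The estimated step is a 1.1-fold lower number from compound 2 to compound 3 (0.04 log units; within the scatter) at its middle. Compound 3 is expected at 65000 nM (30000 nM to 120000 nM).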

Compound 3, half-maximal inhibitory concentration: 31300 nM
Beside the measured number, compound 3's estimate is 2.1-fold (0.32 log units) above it; low and high end bracket the measured number.
By their numbers in this assay, from the lowest: compound 3; then compounds 2 and 1 (each within the scatter of the next).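

In this assay, for the compounds shown here, the group on a saturated chain carbon bound to an amide-type nitrogen in a ring now clearly affects the result, which the first pair of compounds did not show. Putting 2-methylphenyl in place of 4-methoxyphenyl gives a 2.3-fold lower number from compound 2 to compound 3 (0.36 log units; beyond the scatter), and putting it in place of 4-phenylphenyl gives a 2.6-fold lower number from compound 1 to compound 3 (0.41 log units; beyond the scatter), so compound 3 is the strongest inhibitor of the three. No measurement shown explains this difference.

The swap from compound 2 changes both the group, methoxy to methyl, and the number in its name, 4 to 2, and the compounds shown cannot separate these two changes. Plain phenyl, or an amine or a carboxylic acid on this ring, also remains open.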